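A Difluoromethoxy-to-Methoxymethyl Swap at the Aryl Ring

The compounds below may be only part of what the source reports. "The series", "measured", "known", "first", "only" and "open" are said of these compounds alone.

Compound 1 `FC(F)Oc1ccccc1C1Cc2nccn2C1` carries a difluoromethoxy group on a benzene ring joined to a small fused core. In a functional assay on CHO cells for agonist activity at Alpha-1B adrenergic receptor (Homo sapiens), read by FLIPR and calcium flux (a lower number here means that less compound is needed, a higher number that more compound is needed for the effect), compound 1 has "not determined" (no result reported), so no number is available for it. Two further compounds share a different core. Compound 2 `COc1ccc(C2CCc3nc[nH]c3C2)cc1` gives a limit of the assay in this assay, > 10000 nM. Compound 3 `c1ccc(C2CCc3nc[nH]c3C2)cc1` likewise gives only limits, > 10000 nM; > 10000 nM; > 10000 nM (3 entries), in this assay. These limits, summarised as the limit of > 10000 nM in this assay, at which 1 of the 3 values shown sits, show that neither compound 2 nor compound 3 produced a measurable response, and they tell nothing about compound 1.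

The compound to be measured, compound 4 `COCc1ccccc1C1Cc2nccn2C1`, keeps the core of compound 1 and differs only in one place: methoxymethyl in place of difluoromethoxy on an aromatic carbon. Among the compounds with values here, no measured pair in this set mirrors this change, and compound 1 itself has no number, so the size of the step in this assay cannot be read from the data; the change is small and a step within the usual scatter is expected. Compound 4 is expected to reach about 2000 nM, between 300 nM and 10000 nM.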

Compound 4, half-maximal effective concentration: > 10000 nM
Compound 4 was reported as a limit; the forecaster's own chance of this, stated with the estimate: 40%; middle value at least 5.0-fold (0.69 log units) away from the limit.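

In this assay compound 4 gives > 10000 nM, a limit of the assay and not a number. Within the data shown here, compound 1 has no number here, so no step between compound 1 and compound 4 can be read. The compounds shown leave open whether difluoromethoxy on the shared core gives any measurable response.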